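The source may report more compounds than this note shows. Statements on the series, on what has been measured and on what is new or still open speak of the compounds shown alone.

Measured so far:
- compound 1 `Cc1cc(-c2cccc(C(F)(F)F)c2)cc(C)c1Nc1ccnc(Nc2ccc(C#N)cc2)n1` — 4030 nM
- compound 2 `Cc1cc(-c2cc(Cl)cc(Cl)c2)cc(C)c1Nc1ccnc(Nc2ccc(C#N)cc2)n1` — 4290 nM

In an ADME assay on MT4 cells (Homo sapiens) for cytotoxicity, read by MTT assay, with a stated time of 4 days (on this read-out lower numbers stand for higher toxicity in this test and higher numbers for lower toxicity in this test), compound 1 gives 4030 nM and compound 2 gives 4290 nM. Compound 2 holds the highest of the two numbers, but its nearest neighbour is compound 1 and the two are within the scatter of each other, so no order can be read between them. Going by the values given here, the only measured step is a 1.1-fold higher number from compound 1 to compound 2 (0.03 log units; within the scatter), an exchange of the aryl ring on the shared core that left the read-out essentially unchanged.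

Compound 3 `Cc1cc(C)cc(-c2cc(C)c(Nc3ccnc(Nc4ccc(C#N)cc4)n3)c(C)c2)c1` is the next member and is not yet measured. It differs from compound 2 as follows: 3,5-dimethylphenyl in place of 3,5-dichlorophenyl on an aromatic carbon. Among the compounds with values here, this is again an exchange of the aryl ring at the same place, and the one step that bears on it, a 1.1-fold higher number from compound 1 to compound 2 (0.03 log units; within the scatter), is within the scatter. Within the data shown here, no measured step points in either direction beyond the scatter, and nothing here separates a chlorine-bearing ring from a methyl-bearing one.

For compound 3 the expected step in this assay is therefore a 1.0-fold higher number from compound 2 to compound 3 (0.00 log units; within the scatter), that is, none beyond the scatter. The estimate for compound 3 is 4300 nM, with a range from 1500 nM to 12000 nM.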

Compound 3, half-maximal cytotoxic concentration: 4140 nM
For compound 3 the middle estimate is 1.0-fold (0.02 log units) above the measured one; measured number inside the range.
By their numbers in this assay, from the lowest: compounds 1, 3 and 2 (each within the scatter of the next).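

The ring at this place, on an aromatic carbon para to a large group, carries no halogen in compound 3, unlike in compound 1 and compound 2. In this assay, 3,5-dimethylphenyl in place of 3,5-dichlorophenyl gives a 1.0-fold lower number from compound 2 to compound 3 (0.02 log units; within the scatter) and the same group in place of 3-(trifluoromethyl)phenyl gives a 1.0-fold higher number from compound 1 to compound 3 (0.01 log units; within the scatter), so among these three compounds a ring bearing chlorine or fluorine and a ring bearing only carbon substituents cannot be told apart, and the three cannot be put in any order. Nothing on hand bears on the reason for this result.

All three rings shown are phenyl rings with carbon or halogen substituents, so it stays open whether the read-out would hold with an amine, a hydroxyl or a carboxylic acid on the ring, or with a pyridine ring in its place. From the compounds shown here alone, it also stays open whether a substituent at this place can move the read-out beyond the scatter at all, since every step seen so far lies within it.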